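Shortening 1-aminoethyl to amino: expected cell tolerance

The source may hold more compounds than are shown below. What is called first, only, known or untested is meant among the compounds shown, and "the series" means these compounds.

The study follows small primary amines on a shared saturated core and asks how much of each is tolerated by cells. In an ADME assay on MDCK cells (Canis lupus familiaris) for cytotoxicity, read by CCK-8 assay, with a stated time of 72 h (a lower number here means that less compound is tolerated, a higher number that more compound is tolerated), compound 1 `C[C@H]1[C@H]([C@H](C)N)C[C@@H]2C[C@H]1C2(C)C` gives > 300000 nM, which is a limit of the assay rather than a number. Compound 2 `CC1(C)[C@@H]2CC[C@@]1(C)[C@@H](CN)C2` likewise reaches only a limit of > 300000 nM in this assay. Compound 3 `C[C@@H](N)[C@H]1C[C@H]2CC[C@]1(C)C2(C)C`, bearing a 1-aminoethyl group on the core, also stands at a limit of > 300000 nM. The step that the two limits leave unreadable from compound 2 to compound 3 cannot be read; both of its values are limits. The whole picture so far is the limit of > 300000 nM in this assay, at which 3 of the 3 values shown sit.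

Compound 4 `CC1(C)[C@@H]2CC[C@@]1(C)[C@@H](N)C2` differs from compound 3 by amino in place of 1-aminoethyl on a saturated ring carbon. No measured step bears readably on this change; all that is known is that every compound shown is tolerated up to the limit. The step of a number no higher from compound 3 to compound 4 (the limit leaves the size open) expected in this assay is therefore none beyond the scatter. Compound 4 is estimated at 300000 nM, with a range from 150000 nM to 600000 nM, and most probably will again be reported only as a limit.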

Compound 4, minimum cytotoxic concentration: > 300000 nM
Compound 4 gave a limit, no number (the forecaster's own chance of this, stated with the estimate: 85%); the middle value sits exactly at the limit.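

Compound 4 gives > 300000 nM in this assay, which is a limit, so the steps to it from compound 2 and from compound 3 cannot be read. What the compounds shown leave open is the concentration at which any of them becomes cytotoxic, since the picture remains (the limit of > 300000 nM in this assay, at which 4 of the 4 values shown sit)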